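The source may hold more compounds than are shown below. What is called first, only, known or untested is meant among the compounds shown, and "the series" means these compounds.

Compound 1 `O=C(O)CCCSCCN1C(=O)SC[C@@H]1/C=C/[C@@H](O)Cc1ccccc1` was tested in an assay on CHO cells for displacement of a labelled ligand from prostaglandin E2 receptor EP2 subtype (Mus musculus), read by scintillation counting, with a stated time of 60 min; a higher number here means a weaker inhibitor, a lower number a stronger inhibitor. In this assay compound 1 gives > 10000 nM, which is a limit of the assay rather than a number, so compound 1 sits at the weak end of what has been measured so far: the limit of > 10000 nM in this assay, at which 1 of the 2 values shown sits. A second compound, compound 2 `Cc1cccc(C[C@H](O)/C=C/[C@H]2CCC(=S)N2CCSCCCC(=O)O)c1`, is built on a different core, and in this assay compound 2 gives 1700 nM. The next compound, compound 3 `CCc1cccc(C[C@H](O)/C=C/[C@H]2CSC(=O)N2CCSCCCC(=O)O)c1`, keeps the core of compound 1 and differs from it in one place: ethyl in place of hydrogen on an aromatic carbon. For the measured compounds named here, no measured pair shows this change on its own, so its size can only be guessed. A step of an at least 2.0-fold lower number from compound 1 to compound 3 (0.30 log units; that floor lies within the scatter) is expected, toward stronger binding, though a result that again reaches the limit would not surprise. The estimate for compound 3 is 5000 nM, with a range from 1500 nM to 20000 nM.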

Compound 3, inhibition constant: > 10000 nM
Compound 3: only a limit was reported; the forecaster's own chance of this, stated with the estimate: 40%; middle value at least 2.0-fold (0.30 log units) from the limit.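

Compound 1 and compound 3 both end at a limit of the assay and not at a number, so no step between them can be read: the limit of > 10000 nM in this assay, at which 2 of the 3 values shown sit.

The compounds shown leave open how strongly either one binds, and whether ethyl in place of hydrogen on an aromatic carbon changes binding at all.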